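From chloro to cyano on low-scoring compound 3

The source may report more compounds than this note shows. Statements on the series, on what has been measured and on what is new or still open speak of the compounds shown alone.

In a functional assay on A549 cells (Homo sapiens) for inhibition, read by CCK-8 assay, with a stated time of 72 h, tested at 1 uM (a lower number here means less inhibition of growth, a higher number more inhibition of growth at the concentration tested), compound 3 `CN(C)C(=O)c1cc2cnc(Nc3ccc(NC(=O)C4(C(=O)Nc5cccc(Cl)c5)CC4)cc3)nc2n1C1CCCC1` gives 8.3%, the lowest of three values, while compound 1 `COC(=O)c1ccc(NC(=O)C2(C(=O)Nc3ccc(Nc4ncc5cc(C(=O)N(C)C)n(C6CCCC6)c5n4)cc3)CC2)cc1` gives 77.1% and compound 2 `COc1ccc(NC(=O)C2(C(=O)Nc3ccc(Nc4ncc5cc(C(=O)N(C)C)n(C6CCCC6)c5n4)cc3)CC2)cc1` gives 74.4%. Compound 4 `CN(C)C(=O)c1cc2cnc(Nc3ccc(NC(=O)C4(C(=O)Nc5cccc(C#N)c5)CC4)cc3)nc2n1C1CCCC1` has cyano in place of chloro on an aromatic carbon. For the measured compounds named here, no measured step makes this exact change. The closest evidence comes from installing 3-chlorophenyl, which gave a number 68.8 percentage points lower from compound 1 to compound 3 (beyond the scatter) and a number 66.1 percentage points lower from compound 2 to compound 3 (beyond the scatter). Methoxy in place of methoxycarbonyl gave only a number 2.7 percentage points lower from compound 1 to compound 2 (within the scatter). These steps show that this group can matter greatly, but not how cyano will compare with chloro. A modest, uncertain rise is therefore expected, with an estimated a number 11.7 percentage points higher from compound 3 to compound 4 (beyond the scatter). Compound 4 is expected to give 20%, within an estimated range of 3% to 60%.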

Compound 4, percent growth inhibition at one concentration: 70.8%
Compound 4: the middle estimate sits 50.8 percentage points below what was measured; measured number above the stated range.
By their numbers in this assay, from the lowest: compound 3; then compounds 4, 2 and 1 (each within the scatter of the next).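

Cyano in place of chloro on this aromatic carbon moves the number sharply (a number 62.5 percentage points higher from compound 3 to compound 4 (beyond the scatter)), so the low value of compound 3 is tied to chloro, not to every group at this place on the ring. The 3-cyanophenyl group also performs on a par with the two other aryl groups shown (a number 3.6 percentage points lower from compound 2 to compound 4 (within the scatter); a number 6.3 percentage points lower from compound 1 to compound 4 (within the scatter)). Among these compounds, only the 3-chlorophenyl group stands apart.

As far as these compounds go, whether an amine or a carboxylic acid at this place would behave like cyano or like chloro remains open. Nothing available explains the sharp gap between chloro and cyano.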